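The source may report more compounds than this note shows. Statements on the series, on what has been measured and on what is new or still open speak of the compounds shown alone.

Measured so far in a functional assay on A549 cells (Homo sapiens) for cytotoxicity, read by MTT assay, with a stated time of 72 h; a lower number here means a stronger inhibitor, a higher number a weaker inhibitor:

- compound 1 `COc1ccc(Cn2cc(/C=C(/C(=O)O)c3ccccc3)c3cc(OCc4ccccc4)ccc32)cc1`: 1000 nM
- compound 2 `COc1ccccc1/C(=C\c1cn(C(C)=O)c2ccc(OCc3ccccc3)cc12)C(=O)O`: 57200 nM
- compound 3 `CC(=O)n1cc(/C=C(/C(=O)O)c2ccc(Cl)cc2)c2cc(OCc3ccccc3)ccc21`: 52300 nM

Compound 2 stands at the highest number of the three in this assay. Its nearest neighbour is compound 3, and the two lie within the scatter of each other; its furthest neighbour is compound 1, with a gap that lies beyond the scatter. Within the data shown here, compound 1 differs from compound 2 in more than one place, so no single step between them can be separated out; only the two values themselves stand.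

Compound 4 `COc1ccc(/C(=C\c2cn(C(C)=O)c3ccc(OCc4ccccc4)cc23)C(=O)O)cc1` keeps every atom of compound 2 and rearranges one group: 4-methoxyphenyl in place of 2-methoxyphenyl on a double-bonded chain carbon bound to a carbonyl carbon and a double-bonded chain carbon.

Among the measured compounds shown here, the one measured step that bears on this change is the exchange of the same 2-methoxyphenyl for 4-chlorophenyl at the same place, a 1.1-fold lower number from compound 2 to compound 3 (0.04 log units; within the scatter), which gave no change beyond the scatter in this assay. Replacing the aryl group on the double-bonded chain carbon therefore left the number of compound 2 essentially where it was in the only case seen, and the same is expected here: a step within the scatter, in no firm direction, so that compound 4 is expected to behave as an expected 1.1-fold lower number from compound 2 to compound 4 (0.06 log units; within the scatter).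

Compound 4 is estimated at 50000 nM in this assay, with an expected range from 18000 nM to 140000 nM.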

Compound 4, half-maximal inhibitory concentration: > 100000 nM
Compound 4: a limit, no number; the forecaster's own chance of this, stated with the estimate: 10%; at least 2.0-fold (0.30 log units) between middle value and limit.
By their numbers in this assay, from the lowest: compound 1; then compounds 3 and 2 (each within the scatter of the next). At a limit, above all of these: compound 4.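

Compound 4 gives a limit and not a number in this assay: the limit of > 100000 nM in this assay, at which 1 of the 4 values shown sits. With 4-methoxyphenyl in place of 2-methoxyphenyl the step is an at least 1.7-fold higher number from compound 2 to compound 4 (0.24 log units; that floor lies within the scatter), and with methoxy in place of chloro on an aromatic carbon it is an at least 1.9-fold higher number from compound 3 to compound 4 (0.28 log units; that floor lies within the scatter); both are floors, each lies within the scatter as printed, and the real steps may be larger. What the earlier pair did not show is that an exchange on the double-bonded chain carbon bound to a carbonyl carbon and a double-bonded chain carbon can leave the measurable range of this assay, here with the same atoms joined differently, whereas compound 2 and compound 3 both gave numbers.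

As far as these compounds go, how far compound 4 lies past its limit remains unknown, so whether either step truly exceeds the scatter cannot be settled from these values. Also open, from the compounds shown here alone, is whether an amine on this aryl group, in place of the methoxy or the chloro, would give a number or another limit.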